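Fluoro placement across the thiosemicarbazone series

The compounds below may be only part of what the source reports. "The series", "measured", "known", "first", "only" and "open" are said of these compounds alone.

Compound 1 `CNc1c(F)ccc2c(C=NNC(=S)N(C)C)nccc12` gives 272 nM in a functional assay on MIA PaCa-2 cells (Homo sapiens) for cytotoxicity, read by luminescence, with a stated time of 72 h; on this read-out higher numbers stand for weaker inhibition and lower numbers for stronger inhibition. Compound 2 `CNC(=S)N/N=C/c1nccc2cc(F)ccc12` gives 4080 nM in this assay, and compound 3 `CNC(=S)N/N=C/c1nccc2ccccc12` gives 18700 nM. Compound 3 stands highest of the three numbers in this assay; compound 2 is nearest and compound 1 furthest, and both lie beyond the scatter from it. Going by the values given here, the only single-change step measured so far is a 4.6-fold higher number from compound 2 to compound 3 (0.66 log units; beyond the scatter), hydrogen in place of fluoro on an aromatic carbon. Compound 1 differs from compound 3 in more than one place, so its value shows only that a fluorinated and otherwise altered analogue can reach a far lower number.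

Compound 4 `CNC(=S)N/N=C/c1ncc(F)c2ccccc12` differs from compound 3 by fluoro in place of hydrogen on an aromatic carbon. This is the reverse of the measured step in kind, though at another site on the shared core, so that step bears on it only loosely. A return toward the number of compound 2 is plausible but not assured. Compound 4 is therefore expected to show a 2.3-fold lower number from compound 3 to compound 4 (0.37 log units; beyond the scatter) in this assay, a modest lowering. The estimate for compound 4 in this assay is 8000 nM, with a range from 2500 nM to 25000 nM.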

Compound 4, concentration for 90% inhibition: 2080 nM
Beside the measured number, compound 4's estimate is 3.8-fold (0.59 log units) above it; measured number below the stated range.
By their numbers in this assay, from the lowest: compound 1; then compounds 4 and 2 (each within the scatter of the next); then compound 3.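

In this assay, fluoro in place of hydrogen on the aromatic carbon two atoms from the ring nitrogen and para to a group of 7 heavy atoms gives a 9.0-fold lower number from compound 3 to compound 4 (0.95 log units; beyond the scatter), so this position responds to the change by itself, with nothing else on the shared core altered. The earlier single-change step, a 4.6-fold higher number from compound 2 to compound 3 (0.66 log units; beyond the scatter), concerned fluoro at another site, and with this result both fluoro-bearing compounds, compound 2 and compound 4, stand beyond the scatter from compound 3 in the same direction, although the pattern rests on these three compounds alone. No measurement here offers an explanation for the lowering at this position.

The compounds shown leave open whether the response is particular to fluoro or would also appear with chloro, methyl, a nitrile or an amine on the same carbon. They also leave open whether fluoro at this position and fluoro at the site in compound 2 would combine on one molecule, and how much of the low number of compound 1, which differs in more than one place, could be reached that way.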